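This account rests on a few compounds, and the source may have more. Where it says the series, first, only, none or still open, it means among the compounds named here.

Measured compounds in a functional assay on NB-4 cells (Homo sapiens) for inhibition, read by XTT assay, with a stated time of 48 h; on this read-out lower numbers stand for stronger inhibition and higher numbers for weaker inhibition:

Compound 1, `COc1ccc(C(=O)/C(=C/c2ccc(Cl)cc2Cl)CCOC(C)=O)cc1`, gives 34800 nM.
Compound 2, `COc1ccc(C(=O)/C(=C/c2c(F)c(F)c(F)c(F)c2F)CCOC(C)=O)cc1`, gives 28500 nM.
Compound 3, `COc1ccc(C(=O)/C(=C/c2ccc(Cl)cc2Cl)CC(C)OC(C)=O)cc1`, gives 36800 nM.

All three share an arrangement in which a carbonyl group carries a methoxy-substituted ring on one side and a double bond on the other, with a short chain ending in an acetate ester. Compound 1 and compound 3 carry the same aromatic ring on the double bond; compound 2 carries a different one, and the difference between the core of compound 1 and the core of compound 2 is not broken down here. In this assay the three numbers of compound 1, compound 2 and compound 3 all sit within the scatter of one another, so none of them can be called stronger or weaker than the others.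

One structural change appears twice. From compound 1 to compound 3 it reads (methyl in place of hydrogen on a saturated chain carbon bound to an oxygen next to a carbonyl group and a saturated chain carbon), and it produced a 1.1-fold higher number from compound 1 to compound 3 (0.02 log units; within the scatter). From compound 2 to compound 4, `COc1ccc(C(=O)/C(=C/c2c(F)c(F)c(F)c(F)c2F)CC(C)OC(C)=O)cc1`, the same change is made: methyl in place of hydrogen on a saturated chain carbon bound to an oxygen next to a carbonyl group and a saturated chain carbon. Both occur at the same place, so this is the same change on a different core.

For compound 4 the expected step is a 1.1-fold higher number from compound 2 to compound 4 (0.02 log units; within the scatter), because a 1.1-fold higher number from compound 1 to compound 3 (0.02 log units; within the scatter) stayed within the scatter. Compound 4 is therefore estimated at 30000 nM, with a likely range from 15000 nM to 60000 nM.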

Compound 4, half-maximal inhibitory concentration: 49000 nM
Compound 4: middle estimate off by 1.6-fold (0.21 log units), on the low side, and the stated range covers the measured number.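

On the core of compound 2, placing a methyl where a hydrogen stood on the saturated chain carbon, which turns 2-acetoxyethyl into 2-acetoxypropyl, gave a 1.7-fold higher number from compound 2 to compound 4 (0.24 log units; within the scatter) in this assay. Set beside the same change on the core of compound 1, the two steps cannot be told apart: the same change on two cores in this assay, a 1.1-fold higher number (0.02 log units; within the scatter) from compound 1 to compound 3 and a 1.7-fold higher number (0.24 log units; within the scatter) from compound 2 to compound 4, 1.6-fold (0.21 log units) apart, within the scatter of two such steps. This shows that, on these two cores, the change carries over without a step beyond the ordinary spread of repeated measurements, but it does not show that the methyl has no effect at all, and two pairs say nothing firm about how the same change would behave on a further core.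

The compounds shown leave open what happens when the acetate ester at the end of the chain gives way to another group, such as a free alcohol, an amide, an amine or a carboxylic acid. They also leave open whether a larger group than methyl at the same place, such as ethyl, or a longer chain would move the number in this assay by more than the scatter.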